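Notes on an acetoxy replacement at compound 2

The source may report more compounds than this note shows. Statements on the series, on what has been measured and on what is new or still open speak of the compounds shown alone.

Measured in a functional assay on Bel7402/5-FU cells (Homo sapiens) for cytotoxicity, read by MTT assay, with a stated time of 72 h; on this read-out higher numbers stand for weaker inhibition and lower numbers for stronger inhibition:
compound 1 `O=C1C=CCC/C1=C\C=C\c1ccccc1`: 4200 nM
compound 2 `Cc1ccc(/C=C/C=C2\CCC=CC2=O)cc1`: 5800 nM
compound 3 `O=C1C=CCC/C1=C\C=C\c1ccccc1[N+](=O)[O-]`: 5200 nM

In this assay compound 2 gives 5800 nM, which places it in one group with the other two compounds, all within the scatter of each other. The next compound to be measured is compound 4 `CC(=O)Oc1ccc(/C=C/C=C2\CCC=CC2=O)cc1`, with acetoxy in place of methyl on an aromatic carbon, para to a large group: acetoxy in place of methyl on an aromatic carbon. Among the measured compounds shown here, two measured steps bear on this change: a 1.4-fold higher number from compound 1 to compound 2 (0.14 log units; within the scatter) for methyl in place of hydrogen, and a 1.2-fold higher number from compound 1 to compound 3 (0.09 log units; within the scatter) for nitro in place of hydrogen. Both are small. For the measured compounds named here, no measured compound carries acetoxy, so this evidence is indirect and the range is kept wide. No shift beyond the scatter is expected in this assay, in either direction. The expected step is a 1.2-fold lower number from compound 2 to compound 4 (0.08 log units; within the scatter). For compound 4 the estimated value is 4800 nM, with an expected range from 2200 nM to 9500 nM.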

Compound 4, half-maximal inhibitory concentration: 4100 nM
Compound 4: middle estimate off by 1.2-fold (0.07 log units), on the high side; measured number inside the range.
By their numbers in this assay, from the lowest: compounds 4, 1, 3 and 2 (each within the scatter of the next).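

On an aromatic carbon para to a large group, acetoxy brings more heavy atoms than methyl and adds hydrogen-bond acceptors, yet this assay shows only a small step (a 1.4-fold lower number from compound 2 to compound 4 (0.15 log units; within the scatter)), and the comparison with hydrogen at the same place is just as small (a 1.0-fold lower number from compound 1 to compound 4 (0.01 log units; within the scatter)). Hydrogen, methyl and acetoxy at this place therefore all fall within the scatter of one another, which the methyl step alone could not show for a group of this size. No available evidence bears on why this change leaves the number so little moved.

As far as these compounds go, whether an amine or a carboxylic acid at this place would give a step beyond the scatter remains open. So does whether a longer chain on the ester would do so.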